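Benzylic aryl swap: fluoro for methoxy at the pendant ring

The source may report more compounds than this note shows. Statements on the series, on what has been measured and on what is new or still open speak of the compounds shown alone.

Of the compounds shown here, three have been measured so far in an in vitro functional assay on cells for agonist activity at Bombesin receptor subtype-3 (Homo sapiens), read by luminescence and calcium flux; a lower number here means that less compound is needed, a higher number that more compound is needed for the effect. Compound 1 `Cc1ccccc1Cc1cnc(CCc2ccc(-c3ccccc3C(=O)O)cc2)[nH]1` gives 127 nM, compound 2 `O=C(O)c1ccccc1-c1ccc(CCc2ncc(CC3CCOCC3)[nH]2)cc1` gives 338 nM and compound 3 `COc1cccc(Cc2cnc(CCc3ccc(-c4ccccc4C(=O)O)cc3)[nH]2)c1` gives 4120 nM. Compound 3 thus stands at the highest number of the three, as the steps of a 32-fold higher number from compound 1 to compound 3 (1.51 log units; beyond the scatter) and a 12-fold higher number from compound 2 to compound 3 (1.09 log units; beyond the scatter) show; the smaller step of a 2.7-fold higher number from compound 1 to compound 2 (0.43 log units; beyond the scatter) separates the other two.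

Compound 4 `O=C(O)c1ccccc1-c1ccc(CCc2ncc(Cc3cccc(F)c3)[nH]2)cc1` differs from compound 3 in one place: fluoro in place of methoxy on an aromatic carbon, on an aromatic carbon of a six-membered aromatic ring of carbon only, meta to a large group. Within the data shown here, no measured step in this set exchanges one substituent of that pendant ring for another; the steps seen so far all replace the whole group on the saturated chain carbon bound to an aromatic carbon, and they were large or modest. The present change is smaller in scope than any of them, so it is expected to move the number in this assay by less than those steps did, with the direction open.

On that basis compound 4 is estimated at 1500 nM, within 400 nM to 6000 nM, which would be a step of a 2.7-fold lower number from compound 3 to compound 4 (0.44 log units; beyond the scatter).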

Compound 4, half-maximal effective concentration: 159 nM
For compound 4 the middle estimate is 9.4-fold (0.97 log units) above the measured one; the measured number lies below the stated range.
By their numbers in this assay, from the lowest: compounds 1 and 4 (each within the scatter of the next); then compound 2; then compound 3.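

Exchanging one substituent on the pendant ring, with the benzylic link and the core kept, gives a large step in this assay, a 26-fold lower number from compound 3 to compound 4 (1.41 log units; beyond the scatter), so this place, meta to a large group, is far more sensitive than the earlier replacements of the whole group could show. The high number of compound 3 therefore cannot be read as a penalty on an aromatic ring at this chain carbon in general: a 1.3-fold higher number from compound 1 to compound 4 (0.10 log units; within the scatter) keeps the 3-fluorophenyl group within the scatter of the 2-methylphenyl group, while a 2.1-fold lower number from compound 2 to compound 4 (0.33 log units; beyond the scatter) sets it modestly ahead of the oxan-4-yl group, leaving the 3-methoxyphenyl group of compound 3 as the one exception among these four compounds. No measurement at hand accounts for the wide gap between the methoxy and fluoro groups at this place.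

Among these compounds, whether methoxy is the unusual group or fluoro the favourable one remains open, as no compound here carries hydrogen, chloro, hydroxy or nitrile on the same aromatic carbon. Also open, as far as these compounds go, is how the fluoro group behaves on another carbon of the pendant ring, and whether a methoxy group there would give a similarly high number.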